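Swapping the benzothiazole substituent for a hydrazine-linked one

A few compounds are considered here, and "the series" means these few. Any claim that something is new, unique, unknown or untested is made for them only; others in the source may bear on it.

Compound 2 `O=c1cc(-c2ccccc2)oc2cc(OCCCCNc3nc4c(F)cc(F)cc4s3)cc(O)c12` gives the higher of the two numbers measured in an ADME assay on MDCK cells (Canis lupus familiaris) for cytotoxicity, read by sulforhodamine B assay, with a stated time of 48 h (on this read-out higher numbers stand for weaker inhibition and lower numbers for stronger inhibition), namely 307 ug/mL; compound 1 `O=c1cc(-c2ccccc2)oc2cc(OCCCCNc3nc4ccc(Br)cc4s3)cc(O)c12` gives 289 ug/mL, so the two sit within the scatter of each other. Compound 3 `O=c1cc(-c2ccccc2)oc2cc(OCCCCNNc3nc4ccccc4s3)cc(O)c12` differs from compound 2 in one place: (1,3-benzothiazol-2-yl)amino in place of 4,6-difluoro-1,3-benzothiazol-2-yl on an amine nitrogen. Going by the values given here, the only measured step that bears on this is the change of the same ring system, a 1.1-fold higher number from compound 1 to compound 2 (0.03 log units; within the scatter), which did not move the number beyond the scatter. A step of about a 1.0-fold lower number from compound 2 to compound 3 (0.01 log units; within the scatter) in this assay is therefore expected, none beyond the scatter. Compound 3 is estimated at 300 ug/mL, with a range from 150 ug/mL to 600 ug/mL.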

Compound 3, half-maximal inhibitory concentration: 316 ug/mL
Compound 3: the middle estimate sits 1.1-fold (0.02 log units) below what was measured; low and high end bracket the measured number.
By their numbers in this assay, from the lowest: compounds 1, 2 and 3 (each within the scatter of the next).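

In this assay the swap to (1,3-benzothiazol-2-yl)amino, which adds a nitrogen to the link and drops both fluorines, gives a 1.0-fold higher number from compound 2 to compound 3 (0.01 log units; within the scatter) and, set against the 6-bromo-1,3-benzothiazol-2-yl group, gives a 1.1-fold higher number from compound 1 to compound 3 (0.04 log units; within the scatter). So this place on the amine nitrogen has now taken a change to the link itself, not only to the substituents on the ring, with no step beyond the scatter. No supporting evidence is available to explain this. Going by these compounds, whether a carboxylic acid on the ring or a longer chain in the link would move the number stays open.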